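Replacing quinolin-6-yl with 1H-indol-6-yl: what to expect

The compounds below may be only part of what the source reports. "The series", "measured", "known", "first", "only" and "open" are said of these compounds alone.

Values measured in a functional assay on DU-145 cells (Homo sapiens) for inhibition, read by trypan blue exclusion, with a stated time of 72 h (on this read-out higher numbers stand for weaker inhibition and lower numbers for stronger inhibition), are as follows.

compound 1 `Cn1c(=O)c(S(=O)(=O)c2ccccc2)cc2cnc(Nc3ccc4ncccc4c3)nc21` gives 50000 nM
compound 2 `Cn1c(=O)c(S(=O)(=O)c2ccc(F)cc2F)cc2cnc(Nc3ccc4[nH]ncc4c3)nc21` gives 30000 nM
compound 3 `Cn1c(=O)c(S(=O)(=O)c2ccc(F)cc2F)cc2cnc(Nc3ccc4c(c3)CC(=O)N4)nc21` gives 100000 nM

Compound 1 at 50000 nM lies within the usual scatter of both other compounds, so it cannot be ranked against either of them. Compound 4 `Cn1c(=O)c(S(=O)(=O)c2ccccc2)cc2cnc(Nc3ccc4cc[nH]c4c3)nc21` keeps the core of compound 1 and changes one group (1H-indol-6-yl in place of quinolin-6-yl on a nitrogen on an aromatic ring). Here 1H-indol-6-yl stands in place of quinolin-6-yl on a nitrogen on an aromatic ring.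

Among the measured compounds shown here, no measured pair shows this exact swap. For the measured compounds named here, the one measured step at this place (a 3.3-fold higher number from compound 2 to compound 3 (0.52 log units; beyond the scatter)) is modest, and its compounds also differ from compound 1 elsewhere, so it is only a rough guide. Compound 2 carries a group with a five-membered aromatic ring and a six-membered aromatic ring of carbon only, as 1H-indol-6-yl does, and its value of 30000 nM lies within the scatter of the value of compound 1.

In this assay no step beyond the scatter is therefore expected, and the estimated step (a 1.7-fold lower number from compound 1 to compound 4 (0.22 log units; within the scatter)) reflects that. For compound 4 the estimated value is 30000 nM with an expected range of 8000 nM to 100000 nM around it.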

Compound 4, half-maximal inhibitory concentration: 10000 nM
The estimate for compound 4 lay 3.0-fold (0.48 log units) above the measured number; measured number inside the range.
By their numbers in this assay, from the lowest: compound 4; then compounds 2, 1 and 3 (each within the scatter of the next, the first and the last beyond it).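

In this assay, the swap gives a 5.0-fold lower number from compound 1 to compound 4 (0.70 log units; beyond the scatter) with the rest of compound 1 left unchanged. Among the compounds shown here, this is the first step that isolates a change on the core of compound 1, and it shows that the group on this nitrogen can shift the number beyond the scatter on that core, here towards stronger inhibition. The swap changes several features at once, as a six-membered aromatic ring with 1 hetero atom gives way to a five-membered aromatic ring with 1 hetero atom and a hydrogen-bond acceptor gives way to a hydrogen-bond donor, and nothing available explains the step.

This single pair cannot show whether ring size, the hydrogen-bond donor or the position of the ring nitrogen accounts for the lower number. A 1-methyl-1H-indol-6-yl group, which carries a methyl group on the ring nitrogen in place of the hydrogen, or a plain phenyl group at the same place would help to separate these features, and neither is among the compounds shown.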